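Removing the nitro group from a quinolinone hydrazone

The source may hold more compounds than are shown below. What is called first, only, known or untested is meant among the compounds shown, and "the series" means these compounds.

Compound 2 `O=c1[nH]c2ccccc2cc1/C=N/Nc1ccc([N+](=O)[O-])cc1` gives 245000 nM in a functional assay, read by spectrophotometry, with a stated time of 1 h (on this read-out higher numbers stand for weaker inhibition and lower numbers for stronger inhibition), the lowest of the two numbers shown. Within the data shown here, the only other measured compound, compound 1 `NS(=O)(=O)CC(=O)N/N=C/c1cc2ccccc2[nH]c1=O`, gives 8730000 nM in this assay, a markedly higher number that lies beyond the scatter, so compound 2 stands as the stronger inhibitor of the pair. Compound 3 `O=c1[nH]c2ccccc2cc1/C=N/Nc1ccccc1` has not yet been measured. It differs from compound 2 by a single change: hydrogen in place of nitro on an aromatic carbon, on an aromatic carbon of a six-membered aromatic ring of carbon only, para to a large group. Among the measured compounds shown here, no step between measured compounds is available to calibrate this change, and compound 1 is too different in structure to help. The author expects the loss of the nitro group to weaken inhibition modestly, a step of a 2.0-fold higher number from compound 2 to compound 3 (0.31 log units; beyond the scatter) that need not exceed the scatter. Compound 3 is accordingly estimated at 500000 nM, with a range from 150000 nM to 2000000 nM.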

Compound 3, half-maximal inhibitory concentration: 1000000 nM
Estimate against measurement, compound 3: 2.0-fold (0.30 log units) below, within the range that was stated.
By their numbers in this assay, from the lowest: compound 2; then compound 3; then compound 1.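

Hydrogen in place of nitro on an aromatic carbon, para to a large group, gives a 4.1-fold higher number from compound 2 to compound 3 (0.61 log units; beyond the scatter) in this assay, the first measured sign that this position responds to a change in its substituent. The other step, phenyl in place of (sulfamoylmethyl)carbonyl on an amine nitrogen, gives an 8.7-fold lower number from compound 1 to compound 3 (0.94 log units; beyond the scatter), so the lower number of the phenyl compound does not depend on the presence of the nitro group. No measurement shown accounts for the size of either step.

As far as these compounds go, it remains open how other groups at this position, such as an amine, a carboxylic acid or a methoxy group, would compare with nitro and hydrogen. From the compounds shown here alone, it is also open whether the nitro-to-hydrogen step would keep its size on a different core.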